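Amino for Nitro, Measured Once and Expected Again

A few compounds are considered here, and "the series" means these few. Any claim that something is new, unique, unknown or untested is made for them only; others in the source may bear on it.

In a functional assay on the whole organism (strain Sprague-Dawley) for inhibition, with Rattus norvegicus as the target, with a stated time of 10 min (a higher number here means that more compound is needed for the effect, a lower number that less compound is needed), compound 1 `O=C(O)c1cnc(-c2ccccc2[N+](=O)[O-])[nH]c1=O` gives only a limit of the assay, > 50 mg/kg. Compound 2 `Nc1ccccc1-c1ncc(C(=O)O)c(=O)[nH]1` carries amino in place of nitro on an aromatic carbon and gives 50 mg/kg in this assay. The measured step is a number no higher from compound 1 to compound 2 (the limit leaves the size open), and its size cannot be read because one end of it rests on (the limit of > 50 mg/kg in this assay, at which 1 of the 3 values shown sits). Compound 3 `CCOC(=O)c1cnc(-c2cc([N+](=O)[O-])ccc2OCC)[nH]c1=O` gives 5 mg/kg in this assay, the lowest of the two numbers and lower than compound 2 by more than the usual scatter. How the core of compound 3 differs from the core of compound 1 is not broken down here.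

Compound 4 `CCOC(=O)c1cnc(-c2cc(N)ccc2OCC)[nH]c1=O` is to be measured in this assay and carries amino in place of nitro on an aromatic carbon. This is the same kind of change as that from compound 1 to compound 2, but the surroundings differ: there the place was ortho to a large group, here it is meta to a large group and para to an ethoxy group. Since the earlier change gave a number no higher from compound 1 to compound 2 (the limit leaves the size open), compound 4 is expected to show a step of a 1.4-fold higher number from compound 3 to compound 4 (0.15 log units; within the scatter). In this assay compound 4 is therefore estimated at 7 mg/kg, likely between 2 mg/kg and 25 mg/kg.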

Compound 4, dose for 50% inhibition: 0.5 mg/kg
Compound 4: middle estimate off by 14-fold (1.15 log units), on the high side; the whole stated range lies above it.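

In this assay, amino in place of nitro on an aromatic carbon gives a 10-fold lower number from compound 3 to compound 4 (1.00 log units; beyond the scatter). The change thus stands on two cores, and on neither does it raise the number: the same change on two cores in this assay, a number no higher (the limit leaves the size open) from compound 1 to compound 2 and a 10-fold lower number (1.00 log units; beyond the scatter) from compound 3 to compound 4; the limit leaves it open whether they differ. This shows a clear gain on the core of compound 3, but it does not show that a step of this size carries over to the core of compound 1, where the step cannot be read, as one of its ends is a limit of the assay and not a number: the limit of > 50 mg/kg in this assay, at which 1 of the 4 values shown sits.

The compounds shown leave open whether a dimethylamino or an acetylamino group, in the same place para to an ethoxy group, would keep the low number that amino gives on the core of compound 3. They also leave open whether the ethoxy group could give way to a longer chain, such as butoxy, without changing the size of the step from nitro to amino.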